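This account rests on a few compounds, and the source may have more. Where it says the series, first, only, none or still open, it means among the compounds named here.

Among the compounds with values here, compound 2, built as `O=[N+]([O-])c1ccccc1CNc1cc(Br)cc2[nH]ncc12`, is the only compound of this small set for which a single number exists: in an assay for inhibition of Indoleamine 2,3-dioxygenase 1 (Homo sapiens), with stated times of 10 min and 60 min (a lower number here means a stronger inhibitor, a higher number a weaker inhibitor), compound 2 gives 8040 nM. Its companion compound 1, `O=[N+]([O-])c1ccccc1CNc1cccc2[nH]ncc12`, carries no bromine on the shared core, and for compound 1 the read-out in this assay is "nd" (no result reported), meaning that no result was reported, so nothing can be said about what the bromine contributes.

Compound 3, `O=[N+]([O-])c1ccc(O)cc1CNc1cc(Br)cc2[nH]ncc12`, has not yet been measured. It differs from compound 2 in a single place: hydroxy in place of hydrogen on an aromatic carbon. Within the data shown here, no step between two measured compounds with such a change is on record. There is thus no basis in these data for expecting a large shift in either direction; a step that stays within the usual scatter of repeated measurements seems the most likely outcome, with a modest gain as the more probable side if any.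

Accordingly, compound 3 is expected to give about 6000 nM in this assay, with a plausible range from 2000 nM to 20000 nM. That estimate amounts to a step of a 1.3-fold lower number from compound 2 to compound 3 (0.13 log units; within the scatter), expected to lie essentially inside the scatter.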

Compound 3, half-maximal inhibitory concentration: 910 nM
Beside the measured number, compound 3's estimate is 6.6-fold (0.82 log units) above it; the measured number lies below the stated range.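

In this assay, hydroxy in place of hydrogen on an aromatic carbon, para to a nitro group and meta to a large group, gives an 8.8-fold lower number from compound 2 to compound 3 (0.95 log units; beyond the scatter) and this step lies beyond the scatter. Within the data shown here, it is the only step in this set that can be read, and it shows that this position on the six-membered aromatic ring of carbon only is not indifferent to substitution: one added oxygen atom moves the compound towards a stronger inhibitor. Nothing on record bears on why the number moves.

The compounds shown leave open whether this gain is particular to the hydroxy or would also appear with another group in the same place, such as an amine, a methoxy group or a carboxylic acid. They also leave open whether a hydroxy on another aromatic carbon of that ring would give a similar step, what the bromine on the shared core contributes, and whether the hydroxy would have the same effect without that bromine.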